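A few compounds are considered here, and "the series" means these few. Any claim that something is new, unique, unknown or untested is made for them only; others in the source may bear on it.

The measured compounds:
compound 1, `Cc1cc(C)c(NC(=O)N(Cc2cccc(-c3nnnn3C)c2)C2CCCCCC2)c(C)c1`, giving > 1 mg/kg;
compound 2, `COc1ccccc1CN(Cc1cccc(-c2cc[nH]n2)c1)C(=O)Nc1c(SC)cc(C)nc1SC`, giving > 0.1 mg/kg.

In a functional assay on a cell-free system (plasma) with sterol O-acyltransferase, Soat (Rattus norvegicus) as the target (a higher number here means that more compound is needed for the effect, a lower number that less compound is needed), compound 1 gives > 1 mg/kg, which is a limit of the assay and not a measured number; it sits at the limit of > 1 mg/kg in this assay, at which 1 of the 2 values shown sits. Compound 2 gives > 0.1 mg/kg, again only a limit, at the limit of > 0.1 mg/kg in this assay, at which 1 of the 2 values shown sits. Going by the values given here, compound 1 therefore cannot be placed exactly among the values shown, and no pair of compounds differing in a single place has been measured, so there is no measured step to lean on. Compound 3, `Cc1cc(C)c(NC(=O)N(Cc2cccc(-c3c[nH]cn3)c2)C2CCCCCC2)c(C)c1`, is not yet measured. It differs from compound 1 by 1H-imidazol-4-yl in place of 1-methyl-1H-tetrazol-5-yl on an aromatic carbon. With nothing measured to guide it, the step expected in this assay is a step that the limit leaves unreadable from compound 1 to compound 3, no bigger than the scatter in either direction. Compound 3 is thus expected to give about 2 mg/kg, within 0.5 mg/kg to 10 mg/kg.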

Compound 3, dose for half-maximal effect: < 1 mg/kg
Compound 3 ended at the assay's limit; the forecaster's own chance of this, stated with the estimate: 60%; middle value at least 2.0-fold (0.30 log units) from the limit.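

Going by these compounds alone, this is the first pair that differs in a single place, and it gives a first reading of this aromatic carbon in this assay: with 1H-imidazol-4-yl in place of 1-methyl-1H-tetrazol-5-yl, the result is a number no higher from compound 1 to compound 3 (the limit leaves the size open). The size of this step cannot be read because compound 3 gives < 1 mg/kg, which is only a limit of the assay: the limit of < 1 mg/kg in this assay, at which 1 of the 3 values shown sits. Compound 1 gives > 1 mg/kg, which is also only a limit of the assay: the limit of > 1 mg/kg in this assay, at which 1 of the 3 values shown sits.

The exchange swaps the whole ring, so the compounds shown do not separate the hydrogen-bond donor that enters from the loss of ring nitrogens and of the methyl group. Also open, from the compounds shown here alone, is how a carboxylic acid or an amine on this same aromatic carbon would read in this assay.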